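From 2-chlorophenyl to 4-chlorophenyl in a growth inhibition series

The source may hold more compounds than are shown below. What is called first, only, known or untested is meant among the compounds shown, and "the series" means these compounds.

Three compounds have been examined so far. In a functional assay on Bel-7402 cells (Homo sapiens) for inhibition, read by MTT assay, with a stated time of 24 h, tested at 100 ug/mL (on this read-out lower numbers stand for less inhibition of growth and higher numbers for more inhibition of growth at the one concentration tested), compound 1 `O=C(CCCCC(S)CCS)Nc1ccc(Cl)cn1` gives 50.7%, the only numerical result in the set. In this assay compound 2 `O=C(CCCCC(CCSC(=O)c1ccccc1)SC(=O)c1ccccc1)Nc1ccccc1` is recorded as "not active" (no number reported). Compound 3 `O=C(CCCCC(CCSC(=O)c1ccccc1)SC(=O)c1ccccc1)Nc1ccccc1Cl` is also recorded as "not active" (no number reported) in this assay, so it has no single number and stands alongside compound 2 rather than on a scale with compound 1.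

The next compound to be tested is compound 4 `O=C(CCCCC(CCSC(=O)c1ccccc1)SC(=O)c1ccccc1)Nc1ccc(Cl)cc1`, which keeps the core of compound 3 and changes a single group: 4-chlorophenyl in place of 2-chlorophenyl on an amide-type nitrogen. In words, 4-chlorophenyl takes the place of 2-chlorophenyl on an amide-type nitrogen, and the two compounds have the same atoms, joined differently. Within the data shown here, no measured pair in the set isolates this kind of change, so the data give no direct measure of its size. Compound 1 differs from compound 4 in more than this one group and offers little guidance. With compound 3 recorded as "not active" (no number reported), no step beyond the usual scatter is expected in this assay, and compound 4 is expected to remain weak or to be reported without a number. If a number is reported, compound 4 is estimated at 10%, within an expected range of 0% to 30%.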

Compound 4, percent growth inhibition at one concentration: "not active" (no number reported)
Compound 4 has no reported number here; there is nothing to compare the estimate with.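

Compound 3 and compound 4 are both recorded as "not active" in this assay with no number, so no step can be read for the change from 2-chlorophenyl to 4-chlorophenyl. No measured evidence bears on this result. The compounds shown leave open whether the place of the chlorine on this phenyl ring affects growth inhibition at all.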